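The compounds below may be only part of what the source reports. "The series", "measured", "known", "first", "only" and "open" are said of these compounds alone.

Working notes on the series. Compound 1 `CC(=O)/C(=N\Nc1ccccc1C(F)(F)F)Nc1cccc(Cl)c1` gives 538 nM; 538 nM (2 entries) in an assay on isolated protein for binding affinity to corticotropin-releasing factor receptor 1 (Homo sapiens) (a higher number here means a weaker inhibitor, a lower number a stronger inhibitor), across a pair of entries. Compound 2 `CCOc1cccc(N/C(=N/Nc2ccccc2Cl)C(C)=O)c1` reaches only the limit of this assay, > 10000 nM, not a number (the limit of > 10000 nM in this assay, at which 1 of the 3 values shown sits). Among the compounds with values here, compound 3 `COc1cccc(N/C(=N/Nc2ccccc2C(F)(F)F)C(C)=O)c1` gives 6950 nM in this assay and so carries the only single value beyond the repeated entries of compound 1. Compound 4 `CCOc1cccc(N/C(=N/Nc2ccccc2C(F)(F)F)C(C)=O)c1` differs from compound 3 by methyl in place of hydrogen on a saturated chain carbon bound to an oxygen on an aromatic ring. Within the data shown here, no measured pair isolates this change; the step is expected to be small, weakening or none beyond the scatter. For compound 4 the estimate is 9000 nM, with a range of 3000 nM to 25000 nM, a step of a 1.3-fold higher number from compound 3 to compound 4 (0.11 log units; within the scatter) that is expected rather than known.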

Compound 4, inhibition constant: > 10000 nM
Compound 4 ended at the assay's limit; the forecaster's own chance of this, stated with the estimate: 40%; middle value at least 1.1-fold (0.04 log units) from the limit.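

Within the data shown here, the first readable step at this place, methoxy to ethoxy, is an at least 1.4-fold higher number from compound 3 to compound 4 (0.15 log units; that floor lies within the scatter) in this assay, so no gain appears, and the true loss may exceed that floor. The step for trifluoromethyl in place of chloro on an aromatic carbon cannot be read, as both ends are limits. The value for compound 4 is itself a limit, not a number, and the top of the range is now shared: the limit of > 10000 nM in this assay, at which 2 of the 4 values shown sit.

Going by these compounds, how far compound 4 lies past its limit stays open. So does whether a propoxy chain or an amine at this place would give a readable value.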